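The compounds below may be only part of what the source reports. "The series", "measured", "known", "first", "only" and "open" are said of these compounds alone.

In a physicochemical assay for solubility (on this read-out lower numbers stand for lower solubility and higher numbers for higher solubility), compound 1 `C[C@@H]1CN(c2c(C#N)c(C(F)F)nn2-c2ccc(S(C)(=O)=O)cn2)[C@H](C)CO1` reads > 200 ug/mL, which is a limit of the assay and not a number. Compound 2 `CC1CCCN(c2c(C#N)c(C(F)(F)F)nn2-c2ccc(S(C)(=O)=O)cn2)C1` gives 100 ug/mL. Compound 3 `CS(=O)(=O)c1ccc(-n2nc(C(F)(F)F)cc2NCC2CC2)nc1` offers no number to start from, since its result stands as "not determined" (no result reported). The next compound to be tested is compound 4 `CS(=O)(=O)c1ccc(-n2nc(C(F)(F)F)cc2OCC2CCC2)nc1`. The structural change is cyclobutylmethoxy in place of (cyclopropylmethyl)amino on an aromatic carbon, with cyclobutylmethoxy in place of (cyclopropylmethyl)amino on an aromatic carbon. Going by the values given here, no measured pair of compounds shows this change, so the size of the step remains a judgement. A moderate downward step is expected, taking compound 4 under compound 2 and its 100 ug/mL. The estimate for compound 4 is 30 ug/mL, with an expected range from 5 ug/mL to 120 ug/mL.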

Compound 4, solubility: 100 ug/mL
The estimate for compound 4 lay 3.3-fold (0.52 log units) below the measured number; measured number inside the range.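

Going by these compounds alone, compound 3 has no number in this assay, so no step to compound 4 can be read. Still open is how (cyclopropylmethyl)amino and cyclobutylmethoxy compare on the shared core, and where compound 1 truly lies: the limit of > 200 ug/mL in this assay, at which 1 of the 4 values shown sits.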